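The source may report more compounds than this note shows. Statements on the series, on what has been measured and on what is new or still open speak of the compounds shown alone.

Compound 2 `Cc1cn(Cc2ccc(O)c(C(C)C)c2)c2c(C)cc(OCC(=O)O)cc12` gives 2.77 nM in an assay on HeLa cells for displacement of a labelled ligand from thyroid hormone receptor alpha (Homo sapiens) (a higher number here means a weaker inhibitor, a lower number a stronger inhibitor), the lowest of the two numbers in hand, while compound 1 `Cc1cn(Cc2ccc(O)c(C(C)C)c2)c2ccc(OCC(=O)O)cc12` gives 7.74 nM. Among the measured compounds shown here, the only measured step is a 2.8-fold lower number from compound 1 to compound 2 (0.45 log units; beyond the scatter). Compound 3 `Cc1cn(Cc2ccc(O)c(C(C)C)c2)c2c(Cl)cc(OCC(=O)O)cc12` differs from compound 2 by chloro in place of methyl on an aromatic carbon. For the measured compounds named here, no measured pair swaps methyl for chloro, so the earlier step shows only the scale of what one change at this carbon has done; both groups occupy the same position with one heavy atom each. A step of about the scatter is expected, a 1.1-fold higher number from compound 2 to compound 3 (0.03 log units; within the scatter), in no firm direction. Compound 3 is therefore estimated at 3 nM, with a range of 1.2 nM to 8 nM.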

Compound 3, inhibition constant: 0.51 nM
Compound 3: the middle estimate sits 5.9-fold (0.77 log units) above what was measured, outside the stated range (below it).
By their numbers in this assay, from the lowest: compound 3; then compound 2; then compound 1.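

Chloro in place of methyl in this assay gives a 5.4-fold lower number from compound 2 to compound 3 (0.73 log units; beyond the scatter) so the group at this aromatic carbon matters beyond its count of one heavy atom. Measured against hydrogen, chloro gives a 15-fold lower number from compound 1 to compound 3 (1.18 log units; beyond the scatter) which is a larger step than the one methyl gave (a 2.8-fold lower number from compound 1 to compound 2 (0.45 log units; beyond the scatter)). No measurement at hand explains why chloro and methyl differ here.

Going by these compounds, whether fluoro, bromo or a methoxy group at this carbon would track chloro or methyl remains open. The compounds shown also give no reading of chloro at this carbon in any other assay.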